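Fluoro to Trifluoromethyl and Membrane Permeability

This account rests on a few compounds, and the source may have more. Where it says the series, first, only, none or still open, it means among the compounds named here.

Three compounds have been measured in an ADME assay for permeability, using PAMPA, with a stated time of 3 h; on this read-out lower numbers stand for lower permeability and higher numbers for higher permeability:
compound 1, `O=C(Nc1ccc(F)cc1)c1cc(Cl)ccc1O`, gives 18.2 10^-6 cm/s;
compound 2, `O=C(Nc1cccc(F)c1)c1cc(Cl)ccc1O`, gives 3.7 10^-6 cm/s;
compound 3, `O=C(Nc1ccc(C(F)(F)F)cc1)c1cc(Cl)ccc1O`, gives 6.9 10^-6 cm/s.

Compound 1 and compound 2 are built from the same atoms joined differently; how the two cores differ is not broken down here. Compound 3 arises from compound 1 by the change (trifluoromethyl in place of fluoro on an aromatic carbon), and this gave a 2.6-fold lower number from compound 1 to compound 3 (0.42 log units; beyond the scatter). Compound 2 stands lowest of the three numbers: its gap to compound 3 lies within the scatter, while its gap to compound 1 lies beyond it.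

Compound 4, `O=C(Nc1cccc(C(F)(F)F)c1)c1cc(Cl)ccc1O`, has not yet been measured in this assay. It arises from compound 2 by the change (trifluoromethyl in place of fluoro on an aromatic carbon). The place lines are not identical: in compound 1 to compound 3 the position is para to a large group, in compound 2 to compound 4 it is meta to a large group, so this is the same kind of change rather than the same change.

For compound 4 the step is expected to be a 2.3-fold lower number from compound 2 to compound 4 (0.36 log units; beyond the scatter), which rests on compound 1 to compound 3 having given a 2.6-fold lower number from compound 1 to compound 3 (0.42 log units; beyond the scatter), and on compound 2 starting from 3.7 10^-6 cm/s. Compound 4 is therefore expected to give about 1.6 10^-6 cm/s, with a range from 0.7 10^-6 cm/s to 3.5 10^-6 cm/s.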

Compound 4, apparent permeability: 4.2 10^-6 cm/s
The estimate for compound 4 lay 2.6-fold (0.42 log units) below the measured number, outside the stated range (above it).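

In this assay, among these compounds, trifluoromethyl in place of fluoro on an aromatic carbon gave a 1.1-fold higher number from compound 2 to compound 4 (0.06 log units; within the scatter), so on this core the change produced no step that can be told apart from the scatter. Set beside the earlier step, the same kind of change did not carry over from one core to the other, and the two results differ by more than the scatter allows: the same change on two cores in this assay, a 2.6-fold lower number (0.42 log units; beyond the scatter) from compound 1 to compound 3 and a 1.1-fold higher number (0.06 log units; within the scatter) from compound 2 to compound 4, 3.0-fold (0.48 log units) apart, beyond the scatter of two such steps This rests on only two pairs, in which the change sits at different places on the ring, so the data do not show whether that place or something else in the core accounts for the gap, nor which result a further core would follow.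

All the compounds shown carry only fluoro or trifluoromethyl on the ring that changes, which leaves open how a methyl, a methoxy or a nitrile at those same places would read in this assay. They also leave open whether the step from fluoro to trifluoromethyl would keep either size if the chloro or the hydroxyl of the shared part gave way to another group, such as a bromo or an amine.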